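This account rests on a few compounds, and the source may have more. Where it says the series, first, only, none or still open, it means among the compounds named here.

Measured so far in an assay on isolated protein for inhibition of ubiquitin carboxyl-terminal hydrolase 7 (Homo sapiens), with stated times of 30 min and 2 h; a lower number here means a stronger inhibitor, a higher number a weaker inhibitor:
compound 1, `Cn1nc2c(=O)n(CC3(O)CCN(Cc4ccc(-c5ccncc5)cc4Cl)CC3)cnc2c1-c1ccc(CN)cc1`: 257 nM
compound 2, `Cn1nc2c(=O)n(CC3(O)CCN(Cc4ccc(-c5ccc(C(=O)O)o5)cc4Cl)CC3)cnc2c1-c1ccc(CN)cc1`: 753 nM

Among the measured compounds shown here, compound 2 stands at the higher of the two numbers in this assay; the nearest is compound 1, and the one recorded step, a 2.9-fold higher number from compound 1 to compound 2 (0.47 log units; beyond the scatter), separates them. Compound 3, `Cc1ccc(-c2ccc(CN3CCC(O)(Cn4cnc5c(-c6ccc(CN)cc6)n(C)nc5c4=O)CC3)c(Cl)c2)s1`, is not yet measured. It differs from compound 2 in one place: 5-methylthiophen-2-yl in place of 5-carboxyfuran-2-yl on an aromatic carbon.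

For the measured compounds named here, the single step that bears on this change is a 2.9-fold higher number from compound 1 to compound 2 (0.47 log units; beyond the scatter), in which a five-membered aromatic ring carrying a carboxylic acid replaced pyridin-4-yl at the same aromatic carbon and the number rose modestly in this assay. In compound 3 the 5-carboxyfuran-2-yl leaves and a five-membered aromatic ring with 0 hydrogen-bond donors enters, so the number is expected to move back toward that of compound 1 rather than further up. Nothing else in the series informs the exchange of a furan for a thiophene or the added methyl, so the estimate is kept wide. Compound 3 is estimated at 350 nM in this assay, with a range of 150 nM to 900 nM, which corresponds to an expected step of a 2.2-fold lower number from compound 2 to compound 3 (0.33 log units; beyond the scatter).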

Compound 3, half-maximal inhibitory concentration: 101 nM
Beside the measured number, compound 3's estimate is 3.5-fold (0.54 log units) above it, outside the stated range (below it).
By their numbers in this assay, from the lowest: compound 3; then compound 1; then compound 2.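

At this position, on an aromatic carbon para to a large group and meta to a chloro group, this assay now shows that a five-membered aromatic ring can give a lower number than pyridin-4-yl, with a 2.5-fold lower number from compound 1 to compound 3 (0.41 log units; beyond the scatter), so the earlier rise on leaving pyridin-4-yl does not hold for every five-membered aromatic ring. The change with a 7.5-fold lower number from compound 2 to compound 3 (0.87 log units; beyond the scatter) links two groups that each hold one five-membered aromatic ring with 1 hetero atom, so ring size alone does not set the number here, and compound 3 stands lowest of the three, with its steps to both others beyond the scatter. No available measurement accounts for these differences.

The exchange alters the ring hetero atom and the ring substituent together, so the share of each stays unresolved; 5-methylfuran-2-yl and 5-carboxythiophen-2-yl would separate them. Also open, from the compounds shown here alone, is how the number responds on the thiophene ring to an unsubstituted carbon, a longer chain such as ethyl, or an amine in place of the methyl.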